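A methyl removed from the trimethoxyphenyl group

The compounds below may be only part of what the source reports. "The series", "measured", "known", "first", "only" and "open" are said of these compounds alone.

Within the data shown here, compound 1 `COc1cc(/C=C/C(=O)Nc2cc3c(Nc4ccc(F)c(Cl)c4)ncnc3cc2O[C@H]2CCOC2)cc(OC)c1OC` gives 20500 nM in a functional assay on PC-3 cells (Homo sapiens) for cytotoxicity, read by MTT assay, with a stated time of 72 h (a lower number here means a stronger inhibitor, a higher number a weaker inhibitor), the lower of the two numbers so far, and compound 2 `COc1cc2ncnc(Nc3ccc(F)c(Cl)c3)c2cc1NC(=O)/C=C/c1cc(OC)c(OC)c(OC)c1` gives 38200 nM, with the step of a 1.9-fold higher number from compound 1 to compound 2 (0.27 log units; within the scatter) staying within the scatter. Compound 3 `COc1cc(/C=C/C(=O)Nc2cc3c(Nc4ccc(F)c(Cl)c4)ncnc3cc2O[C@H]2CCOC2)cc(OC)c1O` differs from compound 1 by hydrogen in place of methyl on an oxygen on an aromatic ring, so that 3,4,5-trimethoxyphenyl becomes 4-hydroxy-3,5-dimethoxyphenyl. Among the measured compounds shown here, no measured step touches this group; the only step available, a 1.9-fold higher number from compound 1 to compound 2 (0.27 log units; within the scatter), changes another oxygen and stays within the scatter, so no movement beyond the scatter is expected in this assay in either direction. Compound 3 is therefore estimated at 25000 nM, between 8000 nM and 75000 nM, an expected step of a 1.2-fold higher number from compound 1 to compound 3 (0.09 log units; within the scatter).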

Compound 3, half-maximal inhibitory concentration: 26500 nM
For compound 3 the middle estimate is 1.1-fold (0.03 log units) below the measured one; measured number inside the range.
By their numbers in this assay, from the lowest: compounds 1, 3 and 2 (each within the scatter of the next).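

This is the first change shown on the trimethoxyphenyl group itself: in this assay, going from methoxy to hydroxy is a 1.3-fold higher number from compound 1 to compound 3 (0.11 log units; within the scatter) and so leaves the number within the scatter. This group therefore joins the other oxygen, on the core, as a second place where a single change produces no readable difference. No measured evidence bears on this result. On these data alone, whether an amine in place of this hydroxy, or a longer chain on this oxygen, would move the number beyond the scatter stays open, as does whether the hydroxy would read the same on the core of compound 2.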